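Thiophene and furan dihydropyrimidine esters: adenosine receptor notes

The compounds below may be only part of what the source reports. "The series", "measured", "known", "first", "only" and "open" are said of these compounds alone.

Measured compounds, in an assay on membranes from CHO cells for displacement of a labelled ligand from adenosine receptor A1 (Homo sapiens), read by scintillation counting, with a stated time of 60 min, tested at 1 uM; a higher number here means more inhibition at the concentration tested (going by the name of the read-out), a lower number less inhibition:
compound 1, `CC1=C(C(=O)OCC(C)C)C(c2ccsc2)NC(=S)N1`, gives 8%
compound 2, `CC1=C(C(=O)OC(C)(C)C)C(c2ccsc2)NC(=S)N1`, gives 16%
compound 3, `CC1=C(C(=O)OCC(C)C)C(c2ccco2)NC(=O)N1C`, gives 13%

Compound 1 and compound 2 differ by tert-butyl in place of isobutyl on an oxygen next to a carbonyl group; the step in this assay is a number 8 percentage points higher from compound 1 to compound 2 (within the scatter). Compound 3 carries a different core; the difference between the core of compound 1 and the core of compound 3 is not broken down here, and its value sits close to both compound 1 and compound 2.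

Compound 4, `CC1=C(C(=O)OC(C)(C)C)C(c2ccco2)NC(=O)N1C`, is not yet measured. It differs from compound 3 by tert-butyl in place of isobutyl on an oxygen next to a carbonyl group, the same change as from compound 1 to compound 2, at the same place. Because a number 8 percentage points higher from compound 1 to compound 2 (within the scatter) stayed within the scatter, a similarly small step is expected, a number 5 percentage points higher from compound 3 to compound 4 (within the scatter). Compound 4 is therefore estimated at 18% in this assay, between 5% and 33%.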

Compound 4, a percentage reported as inhibition, at one concentration (the size of the read-out at that concentration, not a potency): 44%
Beside the measured number, compound 4's estimate is 26 percentage points below it, outside the stated range (above it).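

In this assay the step is a number 31 percentage points higher from compound 3 to compound 4 (beyond the scatter). The size of this change therefore does not carry over from one core to the other: the same change on two cores in this assay, a number 8 percentage points higher (within the scatter) from compound 1 to compound 2 and a number 31 percentage points higher (beyond the scatter) from compound 3 to compound 4, 23 percentage points apart, beyond the scatter of two such steps This rests on one pair per core, read at a single concentration, and it does not show which of the differences between the two cores goes with the larger step, or how the step would behave on a third core.

Still open, on these data alone, is how a longer chain or a cyclopentyl group on the same oxygen would compare with tert-butyl on either core. As far as these compounds go, an amide in place of the ester is equally open.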